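Halogen pattern on the phenyl group: outlook for compound 3

This account rests on a few compounds, and the source may have more. Where it says the series, first, only, none or still open, it means among the compounds named here.

Compound 2 `FC(F)(F)c1c(CN2CCC(c3ccccc3Cl)CC2)ccn2c(CC3CC3)nnc12` gives 13.5 nM in an assay on CHO cells for positive allosteric modulation of metabotropic glutamate receptor 2 (Homo sapiens), read by scintillation counting, with a stated time of 30 min (on this read-out higher numbers stand for an effect only at larger amounts of compound and lower numbers for an effect already at smaller amounts), and stands alongside compound 1 `Fc1ccccc1C1CCN(Cc2ccn3c(CC4CC4)nnc3c2C(F)(F)F)CC1`, which gives 15 nM in this assay; the two numbers sit within the scatter of each other, as the step of a 1.1-fold lower number from compound 1 to compound 2 (0.05 log units; within the scatter) shows. Compound 3 `Fc1cccc(F)c1C1CCN(Cc2ccn3c(CC4CC4)nnc3c2C(F)(F)F)CC1` has not been measured. It differs from compound 2 by 2,6-difluorophenyl in place of 2-chlorophenyl on a saturated ring carbon. Within the data shown here, the only measured step touching this phenyl group, a 1.1-fold lower number from compound 1 to compound 2 (0.05 log units; within the scatter), exchanged one halogen for another and left this assay essentially unchanged. Among the measured compounds shown here, the move to 2,6-difluorophenyl has no direct counterpart among the measured pairs, so the basis is thin, but nothing points to a shift in either direction. The expected step is therefore none beyond the scatter, a 1.3-fold higher number from compound 2 to compound 3 (0.12 log units; within the scatter). Compound 3 is estimated at 18 nM, with a range from 7 nM to 45 nM.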

Compound 3, half-maximal effective concentration: 9.7 nM
The estimate for compound 3 lay 1.9-fold (0.27 log units) above the measured number; measured number inside the range.
By their numbers in this assay, from the lowest: compounds 3, 2 and 1 (each within the scatter of the next).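

Compound 3 shows that this position on the saturated ring carbon accepts a second halogen, not only an exchange of one halogen for another: in this assay the move to 2,6-difluorophenyl gives a 1.4-fold lower number from compound 2 to compound 3 (0.14 log units; within the scatter). The added fluoro gives a 1.5-fold lower number from compound 1 to compound 3 (0.19 log units; within the scatter), so compounds 1, 2 and 3 form a flat set with no step beyond the scatter, and none of the three halogen patterns stands apart. No evidence available here bears on why these steps remain so small.

The compounds shown leave open whether any halogen is needed on this phenyl group, as all three carry at least one. They also leave open how the series would read in this assay with an amine, a carboxylic acid or a methoxy group on the phenyl ring.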